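Fluorine and Methoxy Swapped for Ethoxy: Cytotoxicity Outlook

This account rests on a few compounds, and the source may have more. Where it says the series, first, only, none or still open, it means among the compounds named here.

Three compounds with one shared core have so far been run through an ADME assay on BJ cells (Homo sapiens) for cytotoxicity, read by CellTiter-Glo and resazurin assay, with a stated time of 72 h; on this read-out lower numbers stand for an effect already at smaller amounts and higher numbers for an effect only at larger amounts of compound. Compound 1, `CCOC(=O)CCCCCOc1cccc(CN(C(=O)c2ccc(-c3cccc(-c4ccccc4)c3)cc2)C(C)C)c1`, gives > 26000 nM in this assay, which is a limit of the assay and not a number. Compound 2, `CCOC(=O)CCCCCOc1cccc(CN(C(=O)c2ccc(-c3ccc(C(C)=O)s3)cc2)C(C)C)c1`, also reaches a limit, with > 26000 nM in this assay. Compound 3, `CCOC(=O)CCCCCOc1cccc(CN(C(=O)c2ccc(-c3cccc(OCC)c3)cc2)C(C)C)c1`, stands at > 22300 nM in this assay, again a limit rather than a measured number. Because the limit of > 22300 nM in this assay, at which 1 of the 3 values shown sits, and the limit of > 26000 nM in this assay, at which 2 of the 3 values shown sit, hold all three values, the steps a step that the two limits leave unreadable from compound 1 to compound 2, a step that the two limits leave unreadable from compound 1 to compound 3 and a step that the two limits leave unreadable from compound 2 to compound 3 cannot be sized in either direction; all that can be said is that none of the three compounds showed a cytotoxic effect within the tested range.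

Compound 4, `CCOC(=O)CCCCCOc1cccc(CN(C(=O)c2ccc(-c3cc(F)cc(OC)c3)cc2)C(C)C)c1`, carries the change (3-fluoro-5-methoxyphenyl in place of 3-ethoxyphenyl on an aromatic carbon). Within the data shown here, none of the measured steps can be read, so no direction for this step can be drawn from them; the expectation is a step of no readable size, with compound 4 most likely again at a limit. The expected step from compound 3 is a step that the limit leaves unreadable from compound 3 to compound 4. Compound 4 is therefore estimated at 30000 nM in this assay, within a range from 15000 nM to 100000 nM.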

Compound 4, half-maximal effective concentration: > 26000 nM
Compound 4: a limit, no number (the forecaster's own chance of this, stated with the estimate: 85%); the middle value is on the limit's open side.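

Among these compounds, compound 4, like compound 1, compound 2 and compound 3, ends at a limit of this assay and not at a number, so no step from any of those three to compound 4 can be read. The compounds shown leave open at what concentration, if any, each would affect these cells, and whether swapping the group on the aromatic carbon changes that concentration.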